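Aryl fluoro for trifluoromethyl in a dienone series

The source may report more compounds than this note shows. Statements on the series, on what has been measured and on what is new or still open speak of the compounds shown alone.

Compound 1 `CC1=C(/C=C/C(=O)/C=C/c2cccc(C(F)(F)F)c2)C(C)(C)CCC1` and compound 2 `CC1=C(/C=C/C(=O)/C=C/c2cccc(F)c2)C(C)(C)CCC1` share one core; compound 3 `CC1=CCCC(C)(C)C1/C=C/C(=O)/C=C/c1ccccc1C(F)(F)F` and compound 4 `CC1=CCCC(C)(C)C1/C=C/C(=O)/C=C/c1ccccc1F` share another, and the difference between the two cores is not broken down here. In a functional assay on LNCaP cells (Homo sapiens) for cytotoxicity, read by MTT assay, with a stated time of 72 h (a higher number here means a weaker inhibitor, a lower number a stronger inhibitor), compound 1 gives 2800 nM, compound 2 gives 12900 nM and compound 3 gives 22600 nM. The change from compound 1 to compound 2 is fluoro in place of trifluoromethyl on an aromatic carbon, placed meta to a large group, and it made a step of a 4.6-fold higher number from compound 1 to compound 2 (0.66 log units; beyond the scatter). The change from compound 3 to compound 4 is fluoro in place of trifluoromethyl on an aromatic carbon, placed ortho to a large group; it is the same kind of change, not the same one, since the place around it differs. Among the measured compounds shown here, with only one measured instance of this change, the step for compound 4 is expected to be of similar size, because in this assay the step from compound 1 to compound 2 was a 4.6-fold higher number from compound 1 to compound 2 (0.66 log units; beyond the scatter). The step from compound 3 to compound 4 is therefore estimated at a 3.5-fold higher number from compound 3 to compound 4 (0.55 log units; beyond the scatter). Compound 4 is expected to give about 80000 nM, within 30000 nM to 250000 nM.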

Compound 4, half-maximal inhibitory concentration: 1600 nM
Compound 4: middle estimate off by 50-fold (1.70 log units), on the high side; the whole stated range lies above it.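

In this assay, fluoro in place of trifluoromethyl on an aromatic carbon, ortho to a large group, gave a 14-fold lower number from compound 3 to compound 4 (1.15 log units; beyond the scatter), and this step runs opposite to the one on the core of compound 1: the same change on two cores in this assay, a 4.6-fold higher number (0.66 log units; beyond the scatter) from compound 1 to compound 2 and a 14-fold lower number (1.15 log units; beyond the scatter) from compound 3 to compound 4, 65-fold (1.81 log units) apart, beyond the scatter of two such steps For these two pairs, then, the step measured on one core did not carry to the other in either direction or size, and a result for this change on one core is a poor guide to its result on the other. The pairs differ both in the core and in the place of the group on the aromatic ring, and two pairs cannot show which of these matters or give any general rule for the series.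

Still open, on these data alone, is how fluoro and trifluoromethyl compare at one fixed place on the aromatic ring when only the core changes. Also open, as far as these compounds go, is whether a nitrile or an amine at the place held by fluoro in compound 4 would keep the number of compound 4 or return towards that of compound 3.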